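The compounds below may be only part of what the source reports. "The series", "measured", "known", "first", "only" and "open" are said of these compounds alone.

Compound 1 `COc1ccc2c(=O)c(/C=C/C(=O)Nc3cccc(Cl)c3)coc2c1`: 11900 nM
Compound 2 `COc1ccc2c(=O)c(/C=C/C(=O)Nc3ccccc3)coc2c1`: > 100000 nM
Compound 3 `COc1ccc2c(=O)c(/C=C/C(=O)Nc3ccccc3Cl)coc2c1`: 22400 nM

Of the compounds shown here, three sharing one core have been measured in a functional assay on HeLa cells (Homo sapiens) for inhibition, read by MTT assay, with a stated time of 48 h; a higher number here means a weaker inhibitor, a lower number a stronger inhibitor. Compound 1 gives 11900 nM and compound 3 gives 22400 nM; the step between them, a 1.9-fold higher number from compound 1 to compound 3 (0.27 log units; within the scatter), lies within the scatter. For compound 2 only a limit is known, > 100000 nM (the limit of > 100000 nM in this assay, at which 1 of the 3 values shown sits). Relative to compound 2, both compounds that carry a chloro group give lower numbers: an at least 4.4-fold lower number from compound 2 to compound 3 (0.64 log units; beyond the scatter), and in the other direction an at least 8.4-fold higher number from compound 1 to compound 2 (0.92 log units; beyond the scatter).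

Compound 4 `COc1ccc2c(=O)c(/C=C/C(=O)Nc3ccc(C)cc3)coc2c1` differs from compound 2 by methyl in place of hydrogen on an aromatic carbon. Among the measured compounds shown here, no measured step involves a methyl group, and none involves a substituent in this place on the ring; the only steps that bear on the change are those in which a chloro group entered or left, each at least modest and each giving a lower number for the compound whose ring carries a substituent. Compound 4 is therefore expected to show a drop in the number, estimated as an at least 2.5-fold lower number from compound 2 to compound 4 (0.39 log units; beyond the scatter), though the size is uncertain since the entering group and its place are both new. Compound 4 is estimated at 40000 nM, between 10000 nM and 150000 nM.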

Compound 4, half-maximal inhibitory concentration: 24100 nM
Compound 4: the middle estimate sits 1.7-fold (0.22 log units) above what was measured; low and high end bracket the measured number.
By their numbers in this assay, from the lowest: compounds 1, 3 and 4 (each within the scatter of the next, the first and the last beyond it). At a limit, above all of these: compound 2.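

Methyl in place of hydrogen, para to a large group, gives an at least 4.1-fold lower number from compound 2 to compound 4 (0.61 log units; beyond the scatter) in this assay, so a lower number than that of the unsubstituted phenyl compound is no longer tied to a chloro group or to the ring places held by chloro in the earlier compounds. Against those chloro compounds, the methyl compound gives two different readings: a 1.1-fold higher number from compound 3 to compound 4 (0.03 log units; within the scatter), which leaves the 2-chlorophenyl and 4-methylphenyl compounds indistinguishable, while a 2.0-fold higher number from compound 1 to compound 4 (0.31 log units; beyond the scatter) is a modest step that leaves the 3-chlorophenyl compound with the lower number. Every step from compound 2 gives only a minimum size, since its value is a limit: the limit of > 100000 nM in this assay, at which 1 of the 4 values shown sits.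

The compounds shown leave open whether 4-chlorophenyl would read like 4-methylphenyl, and so whether the group or its place matters more in this series. Among the compounds shown here, they also leave open how an amine, a carboxylic acid or a longer chain at this place on the ring would read, as methyl and chloro are the only groups on the ring here.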